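A few compounds are considered here, and "the series" means these few. Any claim that something is new, unique, unknown or untested is made for them only; others in the source may bear on it.

Compound 1 `Cc1cc(S(=O)(=O)/N=C(\N)n2nccc2-c2ccccc2)c(SCc2ccc(C(F)(F)F)cc2)cc1Cl`: 19000 nM
Compound 2 `Cc1cc(S(=O)(=O)/N=C(\N)n2nccc2-c2ccccc2)c(SCc2cccc3ccccc23)cc1Cl`: 11000 nM

In an ADME assay on HaCaT cells (Homo sapiens) for cytotoxicity, read by MTT assay, with a stated time of 72 h (on this read-out lower numbers stand for stronger inhibition and higher numbers for weaker inhibition), compound 2 gives 11000 nM, one end of a pair whose only gap is the step of a 1.7-fold lower number from compound 1 to compound 2 (0.24 log units; within the scatter), within the scatter, so the two compounds cannot be told apart on this read-out. Compound 3 `Cc1cc(S(=O)(=O)/N=C(\N)n2nccc2-c2ccccc2)c(SCc2ccccc2C(F)(F)F)cc1Cl` is the next member; it differs from compound 2 by 2-(trifluoromethyl)phenyl in place of naphthalen-1-yl on a saturated chain carbon bound to a sulfur. Within the data shown here, the one measured step that bears on this change is a 1.7-fold lower number from compound 1 to compound 2 (0.24 log units; within the scatter), which exchanged a trifluoromethylphenyl group for the naphthalen-1-yl group at the same saturated chain carbon bound to a sulfur and stayed within the scatter. Compound 3 returns a trifluoromethylphenyl group, now 2-(trifluoromethyl)phenyl, so no step beyond the scatter is expected in either direction. Compound 3 is therefore estimated at 15000 nM, in the range 6000 nM to 40000 nM, an expected step of a 1.4-fold higher number from compound 2 to compound 3 (0.13 log units; within the scatter).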

Compound 3, half-maximal inhibitory concentration: 20000 nM
The estimate for compound 3 lay 1.3-fold (0.12 log units) below the measured number; the range from low to high includes it.
By their numbers in this assay, from the lowest: compounds 2, 1 and 3 (each within the scatter of the next).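

At the saturated chain carbon bound to a sulfur, this assay now covers a second exchange between naphthalen-1-yl and a trifluoromethylphenyl group, giving a 1.8-fold higher number from compound 2 to compound 3 (0.26 log units; within the scatter), so the two-ring and one-ring groups still cannot be told apart on this read-out. Exchanging 4-(trifluoromethyl)phenyl for 2-(trifluoromethyl)phenyl at the same place gives a 1.1-fold higher number from compound 1 to compound 3 (0.02 log units; within the scatter), so where the trifluoromethyl group stands on the phenyl ring makes no difference that this read-out can resolve among these compounds. No supporting data are available to explain these numbers.

All three compounds carry a group with carbon-only aromatic rings at this place, so they leave open whether an amine or a carboxylic acid there would give a step beyond the scatter. They also leave open whether a longer chain between the sulfur and the aromatic ring would do so.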